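Lengthening the Chain on the Ring Nitrogen of Compound 3

This account rests on a few compounds, and the source may have more. Where it says the series, first, only, none or still open, it means among the compounds named here.

Compound 1 `COc1ccc(-c2cc3c(OC)cc(OC)cc3n(C)c2=O)cc1` gives 10000 nM in a functional assay on U-87MG ATCC cells for cytotoxicity against U-87 MG (Homo sapiens), read by colorimetric assay and MTT assay; a lower number here means a stronger inhibitor, a higher number a weaker inhibitor.
Compound 2 `CCOC(=O)Cn1c(=O)c(-c2ccc(OC)cc2)cc2c(OC)cc(OC)cc21` gives 10000 nM in this assay.
Compound 3 `COc1ccc(-c2cc3c(OC)cc(OC)cc3n(CC#N)c2=O)cc1` gives 10000 nM in this assay.

Compound 3 sits level with compound 1 and compound 2 in this assay: no change at the digits printed from compound 1 to compound 3 (within the scatter) and no change at the digits printed from compound 2 to compound 3 (within the scatter), both within the scatter. Compound 4 `COc1ccc(-c2cc3c(OC)cc(OC)cc3n(CCCC#N)c2=O)cc1` differs from compound 3 in one place: 2-cyanoethyl in place of cyano on a saturated chain carbon bound to an aromatic nitrogen. Every earlier step at this position, including no change at the digits printed from compound 1 to compound 2 (within the scatter), also changed the group on the saturated chain carbon bound to the aromatic nitrogen without moving the number. The new change is of the same kind, so no shift beyond the scatter is expected; the expected step is no change at the digits printed from compound 3 to compound 4 (within the scatter). Compound 4 is therefore estimated at 10000 nM, within 5000 nM to 20000 nM.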

Compound 4, half-maximal inhibitory concentration: 10000 nM
Compound 4: the middle estimate sits on the measured number at the digits printed; measured number inside the range.
By their numbers in this assay, from the lowest: compounds 1, 2, 3 and 4 (each within the scatter of the next).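

In this assay, lengthening cyanomethyl to 3-cyanopropyl gives no change at the digits printed from compound 3 to compound 4 (within the scatter), so on this saturated chain carbon bound to an aromatic nitrogen, added chain length joins the swaps of end group that left the number in place. The comparisons with the other two compounds agree, with no change at the digits printed from compound 2 to compound 4 (within the scatter) and no change at the digits printed from compound 1 to compound 4 (within the scatter). Nothing available here gives a reason for this flat result. Going by these compounds, whether an amine or a carboxylic acid at the end of this chain, or a chain longer than 3-cyanopropyl, would lower the number remains open.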